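Swapping a Side Chain for a Pyridine Ring

The compounds below may be only part of what the source reports. "The series", "measured", "known", "first", "only" and "open" are said of these compounds alone.

Compound 1, `CN1CCN(CCNCc2cn(-c3ccc([N+](=O)[O-])cc3)nc2-c2ccc(OC(F)(F)F)cc2)CC1`: 4400 nM in an ADME assay on Huh-7 cells (Homo sapiens) for cytotoxicity; on this read-out higher numbers stand for lower toxicity in this test and lower numbers for higher toxicity in this test.
Compound 2, `CCN(CC)CCCNCc1cn(-c2ccc(F)cc2F)nc1-c1ccccc1C`: > 20000 nM, a limit of the assay.
Compound 3, `Cc1ccccc1-c1nn(-c2ccc(F)cc2F)cc1CNCCCN1CCN(C)CC1`: > 20000 nM, also a limit.

Compound 3 sits at the limit of > 20000 nM in this assay, at which 2 of the 3 values shown sit. Compound 4, `Cc1ccccc1-c1nn(-c2ccc(F)cc2F)cc1CNCc1ccncc1`, differs from compound 3 by pyridin-4-yl in place of 2-(4-methylpiperazin-1-yl)ethyl on a saturated chain carbon bound to an amine nitrogen. Among the measured compounds shown here, the only measured step of a related kind, a step that the two limits leave unreadable from compound 2 to compound 3, also reshapes the chain end, but both values are limits, so its size cannot be read. Differing from compound 3 in several places, compound 1 gives 4400 nM, the one value that is a number. With no readable step to build on, compound 4 is expected to stay near the limit, an estimated step of a number no higher from compound 3 to compound 4 (the limit leaves the size open) within the scatter. Compound 4 is estimated at 20000 nM, ranging from 8000 nM to 50000 nM.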

Compound 4, half-maximal cytotoxic concentration: > 20000 nM
Compound 4: no number, only a limit (the forecaster's own chance of this, stated with the estimate: 60%); the middle value sits exactly at the limit.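

Compound 4 gives > 20000 nM, which is a limit and not a number, so its steps from compound 2 and compound 3, both also limits, cannot be read. The compounds shown leave open whether pyridin-4-yl changes the result in this assay at all.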